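Replacing cyclopentyl with 1-phenylethyl on the shared core

The compounds below may be only part of what the source reports. "The series", "measured", "known", "first", "only" and "open" are said of these compounds alone.

Measured so far:
Compound 1 `c1ccc(Cn2nnc3c(NC4CCCC4)ncnc32)cc1`: 127 nM
Compound 2 `Clc1ccccc1Cn1nnc2c(NC3CCCC3)ncnc21`: 21 nM

In an assay on cell membranes for binding affinity to adenosine receptor A1 (Bos taurus), read by radioligand binding (on this read-out lower numbers stand for stronger inhibition and higher numbers for weaker inhibition), compound 1 gives 127 nM, the highest of the two numbers seen; its nearest neighbour is compound 2, reached by a 6.0-fold lower number from compound 1 to compound 2 (0.78 log units; beyond the scatter) through chloro in place of hydrogen on an aromatic carbon. Compound 3 `CC(Nc1ncnc2c1nnn2Cc1ccccc1)c1ccccc1` is not yet measured. Among the measured compounds shown here, it differs from compound 1 by 1-phenylethyl in place of cyclopentyl on a nitrogen on an aromatic ring, a change at a different place from the one probed by compound 2. For the measured compounds named here, no measured step touches this position, so the single step from compound 1 to compound 2 gives no direction for it. A step of about the size seen between compound 1 and compound 2, in either direction, cannot be ruled out, but nothing favours one side. The expectation for compound 3 is therefore a number near that of compound 1, with a wide range: 150 nM (35 nM to 650 nM), which means an expected step of a 1.2-fold higher number from compound 1 to compound 3 (0.07 log units; within the scatter).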

Compound 3, inhibition constant: 438 nM
Beside the measured number, compound 3's estimate is 2.9-fold (0.47 log units) below it, and the stated range covers the measured number.
By their numbers in this assay, from the lowest: compound 2; then compound 1; then compound 3.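

In this assay the group on this nitrogen clearly counts: 1-phenylethyl in place of cyclopentyl brings a 3.4-fold higher number from compound 1 to compound 3 (0.54 log units; beyond the scatter) on the shared core. Of the two groups tried here, the larger one, which carries an aromatic ring of carbon, therefore gives the weaker inhibition, and this position now has a measured direction for this one change. No supporting data bear on why the number rises, so the reason stays unknown.

A benzyl group, a cyclohexyl ring or an open chain such as propyl on this nitrogen could help show whether the kind of ring or the size of the group matters more. Going by these compounds, it also remains open whether the chloro change that separates compound 1 from compound 2 would have a similar effect alongside 1-phenylethyl.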